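Swapping the aryl group on sulfur: compound 1 to compound 4

This account rests on a few compounds, and the source may have more. Where it says the series, first, only, none or still open, it means among the compounds named here.

In a functional assay on HeLa cells (Homo sapiens) for inhibition, read by CCK-8 assay, with a stated time of 72 h, tested at 2 uM (a higher number here means more inhibition of growth at the concentration tested, a lower number less inhibition of growth), compound 1 `Cc1cc(C)cc(SCc2ccc(/C=C/C(=O)Nc3ccccc3N)cc2)c1` stands at 11.7% and lies within the scatter of compound 2 `Nc1ccccc1NC(=O)/C=C/c1ccc(CSc2ccc(Cl)cc2)cc1` at 1.94%. Compound 3 `Nc1ccccc1NC(=O)c1ccc(CSc2cccc(F)c2)cc1` stands at 22.5%. The gap between compound 1 and compound 3 lies beyond the scatter. Compound 4 `Cc1ccc(SCc2ccc(/C=C/C(=O)Nc3ccccc3N)cc2)cc1` carries 4-methylphenyl in place of 3,5-dimethylphenyl on a sulfur and is otherwise unchanged. Among the compounds with values here, the one measured step on that sulfur is a number 9.8 percentage points lower from compound 1 to compound 2 (within the scatter) with 4-chlorophenyl entering in place of the same 3,5-dimethylphenyl. A step of like size is therefore expected in this assay and the estimate is a number 4.7 percentage points lower from compound 1 to compound 4 (within the scatter) with no move beyond the scatter. Compound 4 is expected at 7% with an estimated range of 0% to 17% in this read-out.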

Compound 4, percent growth inhibition at one concentration: 25.5%
For compound 4 the middle estimate is 18.5 percentage points below the measured one; measured number outside the range, above it.
By their numbers in this assay, from the lowest: compounds 2 and 1 (each within the scatter of the next); then compounds 3 and 4 (each within the scatter of the next).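

In this assay, the aryl group on this sulfur does change the read-out: 4-methylphenyl in place of 3,5-dimethylphenyl gives a number 13.8 percentage points higher from compound 1 to compound 4 (beyond the scatter), whereas the earlier step on the same sulfur stayed within the scatter. Methyl in place of chloro on an aromatic carbon gives a number 23.6 percentage points higher from compound 2 to compound 4 (beyond the scatter), so a single group on that aryl ring also separates two compounds. Nothing available explains either step.

Still open, on these data alone, is how a methoxy group, an amine or a carboxylic acid on that aromatic carbon would read. Also open, as far as these compounds go, is where an unsubstituted phenyl on the sulfur would fall relative to compound 1 and compound 4.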